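Notes on the halogen swap leading to compound 4

The source may report more compounds than this note shows. Statements on the series, on what has been measured and on what is new or still open speak of the compounds shown alone.

Compound 3 `Cn1c(COc2cccc(C(=O)O)c2)nc2ccc(Oc3ccc(Cl)cn3)cc21` gives 17 ug/mL in a physicochemical assay for solubility, read by HPLC, measured as thermodynamic solubility, with a stated time of 4 h, at pH 6.8; on this read-out lower numbers stand for lower solubility and higher numbers for higher solubility. Compound 2 `Cn1c(COc2cccc(C(=O)O)c2)nc2ccc(Oc3ccc4c(c3)OCC4)nc21` gives 17 ug/mL in this assay, so compound 3 is level with compound 2 at the digits recorded, and together the two stand highest of the three measured numbers. Compound 1 `Cc1cc(C)cc(Oc2ccc3nc(COc4cccc(C(=O)O)c4)n(C)c3n2)c1` gives 0.5 ug/mL in this assay, the lowest of the set, and compound 3 sits far above it. Among the compounds with values here, the only measured step, a 34-fold higher number from compound 1 to compound 2 (1.53 log units; beyond the scatter), concerns the group carried on the aryl ether oxygen and not the 5-chloropyridin-2-yl ring of compound 3.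

Compound 4 `Cn1c(COc2cccc(C(=O)O)c2)nc2ccc(Oc3ccc(F)cn3)cc21` differs from compound 3 in one place: fluoro in place of chloro on an aromatic carbon. Within the data shown here, no measured pair exchanges one halogen for another, so nothing among the recorded steps bears directly on this change; the large step from compound 1 to compound 2 involves a different part of the molecule and offers no guide to its size. With nothing to support a shift beyond the scatter, the step of a 1.5-fold higher number from compound 3 to compound 4 (0.17 log units; within the scatter) is expected to be small, at most a modest rise. Compound 4 is therefore estimated at 25 ug/mL in this assay, within the range 10 ug/mL to 60 ug/mL.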

Compound 4, solubility: 79 ug/mL
For compound 4 the middle estimate is 3.2-fold (0.50 log units) below the measured one; measured number above the stated range.
By their numbers in this assay, from the lowest: compound 1; then compounds 2 and 3 (each within the scatter of the next); then compound 4.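

In this assay, the fluoro in place of chloro exchange gives a 4.6-fold higher number from compound 3 to compound 4 (0.67 log units; beyond the scatter), at an aromatic carbon two atoms from the ring nitrogen and para to a large group. Within the data shown here, the one measured step among the earlier compounds replaced the whole group on the ether oxygen, whereas this one shows that exchanging one heavy atom for another, with no change in ring or in the counts of hydrogen-bond donors and acceptors, can take the read-out beyond the scatter. No measurement on hand accounts for the rise.

The compounds shown leave open whether the higher number goes with fluoro in particular, or whether a nitrile, a methoxy group or a plain hydrogen at this same place would read at a similar level. They also leave open whether fluoro in place of chloro gives a step of similar size when another group stands on the ether oxygen, or whether it holds only for the 5-chloropyridin-2-yl to 5-fluoropyridin-2-yl pair on this core.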